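Isopropyl in place of benzyl on compound 3

The compounds below may be only part of what the source reports. "The series", "measured", "known", "first", "only" and "open" are said of these compounds alone.

Among the measured compounds shown here, in an ADME assay on BCBL1 cells (Homo sapiens) for cytotoxicity, with a stated time of 7 days (on this read-out higher numbers stand for lower toxicity in this test and lower numbers for higher toxicity in this test), compound 3 `Nc1nc(NCc2ccccc2)c2ncn(/C=C3/CC3(CO)CO)c2n1` gives 19900 nM, the only true number in this small set. Compound 1 `CC(C)CSc1nc(N)nc2c1ncn2/C=C1/CC1(CO)CO` reads > 20000 nM, which is a limit of the assay. Compound 2 `CCCCCCCCOc1nc(N)nc2c1ncn2/C=C1/CC1(CO)CO` reads > 20000 nM, which is also a limit. The set is thus marked by the limit of > 20000 nM in this assay, at which 2 of the 3 values shown sit.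

Compound 4 `CC(C)Nc1nc(N)nc2c1ncn2/C=C1/CC1(CO)CO` differs from compound 3 by one change: isopropyl in place of benzyl on a nitrogen on an aromatic ring. Two measured steps bring in the benzylamino group that compound 4 alters, a number no higher from compound 1 to compound 3 (the limit leaves the size open) and a number no higher from compound 2 to compound 3 (the limit leaves the size open). Neither has a readable size, so they give no firm guide to the effect of this change.

No step beyond the usual scatter is therefore expected in this assay, and compound 4 may well be reported only as a limit. The expected change is a 1.0-fold higher number from compound 3 to compound 4 (0.00 log units; within the scatter). For compound 4 the estimated value is 20000 nM, with an expected range of 10000 nM to 40000 nM.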

Compound 4, half-maximal cytotoxic concentration: > 20000 nM
Compound 4 gave a limit, no number (the forecaster's own chance of this, stated with the estimate: 65%); the middle value lies on the limit itself.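

In this assay, isopropyl in place of benzyl on a nitrogen on an aromatic ring gives a number no lower from compound 3 to compound 4 (the limit leaves the size open), so losing the six-membered aromatic ring of benzyl brings no lower number on this read-out. The steps from compound 1 and from compound 2 to compound 4 cannot be read, since both ends of each are limits, and isopropylamino, isobutylsulfanyl and octyloxy therefore cannot be ranked against one another. The size of the new step stays unknown because the result adds one more value to a shared ceiling: the limit of > 20000 nM in this assay, at which 3 of the 4 values shown sit.

The compounds shown leave open whether a cyclopropylamino group or a longer chain on this nitrogen would give a true number rather than a limit. They also leave open whether any group at this place would bring the number clearly lower.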